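The compounds below may be only part of what the source reports. "The series", "measured", "known", "first", "only" and "open" are said of these compounds alone.

Working notes on a series built on a shared core with a triazole-linked aryl group, tested in a functional assay on SW480 cells (Homo sapiens) for cytotoxicity, read by MTT assay, with a stated time of 4 days; a higher number here means a weaker inhibitor, a lower number a stronger inhibitor. Within the data shown here, compound 1 `COc1ccc(-c2cn(C[C@H]3c4c(ccc(O)c4C)[C@@H]4CC[C@@]5(C)C[C@]43CC5=O)nn2)cc1` is the first entry. In this assay compound 1 gives only a limit, > 20000 nM. Compound 3 `C=C1C[C@]23C[C@@]1(O)CC[C@H]2c1ccc(O)c(C)c1[C@@H]3Cn1cc(-c2ccc(OC)cc2)nn1` has a differently substituted core. In this assay compound 3 also gives only a limit, > 20000 nM. Compound 2 `C=C1C[C@]23C[C@@]1(O)CC[C@H]2c1cc(Br)c(O)c(C)c1[C@@H]3Cn1cc(-c2ccc(C)cc2)nn1` carries a bromine on the core and a 4-methylphenyl on the triazole. In this assay compound 2 likewise gives only a limit, > 20000 nM. Compound 2 therefore stands exactly where every measured entry stands, namely at the limit of > 20000 nM in this assay, at which 3 of the 3 values shown sit; since none of the three values is a number, no ordering among compounds 1, 2 and 3 can be read from them.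

Compound 4 `C=C1C[C@]23C[C@@]1(O)CC[C@H]2c1cc(Br)c(O)c(C)c1[C@@H]3Cn1cc(-c2ccccc2)nn1` differs from compound 2 by hydrogen in place of methyl on an aromatic carbon. Among the measured compounds shown here, no measured pair in this set differs in one place, so no measured step gives a scale for such a change. Given that all three measured values sit at the limit, the step in this assay is expected to be no shift beyond the scatter, a step that the limit leaves unreadable from compound 2 to compound 4. Compound 4 is estimated in this assay at 30000 nM, with an expected range from 10000 nM to 100000 nM. The most likely outcome for compound 4 is a further limit rather than a number.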

Compound 4, half-maximal inhibitory concentration: > 20000 nM
Compound 4 gave a limit, no number; the forecaster's own chance of this, stated with the estimate: 85%; the middle value lies beyond the limit too.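

Compound 2 and compound 4 both give only limits in this assay, so the change from 4-methylphenyl to phenyl yields no readable step, and the series still sits at one ceiling: the limit of > 20000 nM in this assay, at which 4 of the 4 values shown sit.

The compounds shown leave open whether any change to the shared core or the triazole-linked aryl group gives a numerical value in this assay.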